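A Ring Nitrogen in Place of a Bromo Group

A few compounds are considered here, and "the series" means these few. Any claim that something is new, unique, unknown or untested is made for them only; others in the source may bear on it.

Compound 2 `O=C(Nc1ccc(-n2ncc3c(Br)cccc32)cc1)Nc1ccc(Cl)c(C(F)(F)F)c1` gives 1300 nM in a functional assay on NCI-H460 cells (Homo sapiens) for cytotoxicity, read by MTT assay, with a stated time of 72 h; a lower number here means a stronger inhibitor, a higher number a weaker inhibitor. Among the three measured compounds it shows the lowest number, but the others lie within the scatter of it: compound 1 `O=C(Nc1ccc(-n2ncc3c(C(F)(F)F)cccc32)cc1)Nc1ccc(Cl)c(C(F)(F)F)c1` gives 1600 nM, and compound 3 `CNc1cccc2c1cnn2-c1ccc(NC(=O)Nc2ccc(Cl)c(C(F)(F)F)c2)cc1` gives 2600 nM. The steps of a 1.2-fold lower number from compound 1 to compound 2 (0.09 log units; within the scatter), a 1.6-fold higher number from compound 1 to compound 3 (0.21 log units; within the scatter) and a 2.0-fold higher number from compound 2 to compound 3 (0.30 log units; within the scatter) are all within the scatter, so bromo, trifluoromethyl and methylamino on that aromatic carbon give much the same result.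

Compound 4 `O=C(Nc1ccc(-n2ncc3cnccc32)cc1)Nc1ccc(Cl)c(C(F)(F)F)c1` differs from compound 2 by a group of 9 heavy atoms (6 carbon, 3 nitrogen; one five-membered aromatic ring with 2 hetero atoms, one six-membered aromatic ring with 1 hetero atom) in place of a group of 10 heavy atoms (7 carbon, 2 nitrogen, 1 bromine; one five-membered aromatic ring with 2 hetero atoms, one six-membered aromatic ring of carbon only), on an aromatic carbon. Within the data shown here, none of the measured steps touches the six-membered ring itself; each only exchanges one group on an aromatic carbon of it. They bear on compound 4 only in showing that the shared core accepts varied groups at that place; they say nothing about a six-membered ring with one hetero atom replacing a carbon-only ring, nor about losing the bromo altogether. The expected step is therefore small, a 1.9-fold higher number from compound 2 to compound 4 (0.28 log units; within the scatter). Compound 4 is estimated at 2500 nM in this assay, within 800 nM to 8000 nM.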

Compound 4, half-maximal inhibitory concentration: 1400 nM
The estimate for compound 4 lay 1.8-fold (0.25 log units) above the measured number, within the range that was stated.
By their numbers in this assay, from the lowest: compounds 2, 4, 1 and 3 (each within the scatter of the next).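

In this assay, putting the group with a nitrogen in its six-membered ring in place of 4-bromo-1H-indazol-1-yl gives a 1.1-fold higher number from compound 2 to compound 4 (0.03 log units; within the scatter) and so leaves the number within the scatter. Among these compounds, the earlier steps exchanged only one group on the shared core, whereas this one changes the six-membered ring itself and removes the bromo, so the ring can take both changes at once without a readable shift in this assay. Nothing available here accounts for this result.

The compounds shown leave open whether the new ring would accept an amine or a carboxylic acid on one of its carbons, and whether the ring nitrogen would give the same result elsewhere in that ring. On these data alone, all of them also keep the other end of the molecule unchanged, so the effect of a longer chain there remains unknown.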